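Changing the Amine Side of Compound 1

The source may report more compounds than this note shows. Statements on the series, on what has been measured and on what is new or still open speak of the compounds shown alone.

Compound 1 `CCCCN(CCCC)Cc1cn(CC(O)COC(=O)NCc2ccccc2)nn1` gives 42% in an assay on nucleic acid for inhibition of Nucleic Acid, read by fluorescence, tested at 100 uM (a higher number here means more inhibition at the concentration tested (going by the name of the read-out), a lower number less inhibition), the highest of the three measured numbers. Compound 3 `CCCCN(CCCC)Cc1cn(CC(O)COC(=O)c2ccccc2)nn1` gives 12% and compound 2 `CCCCN(CCCC)Cc1cn(CC(O)COCc2ccccc2)nn1` gives 6%; the steps of a number 30 percentage points lower from compound 1 to compound 3 (beyond the scatter) and a number 36 percentage points lower from compound 1 to compound 2 (beyond the scatter) both alter the benzyl end of the molecule, and between compound 2 and compound 3 lies only a number 6 percentage points higher from compound 2 to compound 3 (within the scatter). Compound 4 `CN(Cc1cn(CC(O)COC(=O)NCc2ccccc2)nn1)CC1CCCCC1` instead keeps that end intact and changes the dibutylamino group: (cyclohexylmethyl)(methyl)amino in place of dibutylamino on a saturated chain carbon bound to an aromatic carbon. Within the data shown here, no measured step touches this group, so nothing points toward a gain or a loss, and the expected step is a number 2 percentage points lower from compound 1 to compound 4 (within the scatter), within the usual scatter. Compound 4 is therefore estimated at 40%, in a range from 20% to 60%.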

Compound 4, a percentage reported as inhibition, at one concentration (the size of the read-out at that concentration, not a potency): 32%
Estimate against measurement, compound 4: 8 percentage points above; the range from low to high includes it.
By their numbers in this assay, from the lowest: compounds 2 and 3 (each within the scatter of the next); then compounds 4 and 1 (each within the scatter of the next).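

Among these compounds, this is the first measured change on the amine side of the molecule, and in this assay it reads a number 10 percentage points lower from compound 1 to compound 4 (within the scatter). Replacing dibutylamino with (cyclohexylmethyl)(methyl)amino brings in a six-membered ring of carbon only, yet compound 4 cannot be told apart from compound 1, unlike the changes at the benzyl end. Nothing measured here offers an explanation for this result. Still open, as far as these compounds go, is how an amine such as morpholine or dimethylamino would read in this place, and whether the new group would give a similar result alongside the benzoyl of compound 3.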